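Hydroxy in Place of Nitro: Expecting Little Change

This account rests on a few compounds, and the source may have more. Where it says the series, first, only, none or still open, it means among the compounds named here.

Measured compounds:
compound 1 `CC(=O)N1N=C(c2ccc(Br)cc2)CC1c1cccc(Cl)c1Cl`: 45700 nM
compound 2 `CC(=O)N1N=C(c2ccco2)CC1c1cccc([N+](=O)[O-])c1`: 28900 nM

Within the data shown here, in a functional assay on IMR-32 cells (Homo sapiens) for cytotoxicity, read by sulforhodamine B assay, with a stated time of 48 h (on this read-out lower numbers stand for stronger inhibition and higher numbers for weaker inhibition), compound 2 gives the one of the two numbers that stands lowest, yet compound 1 lies within the scatter of it, so the two compounds cannot be told apart. Compound 3 `CC(=O)N1N=C(c2ccco2)CC1c1cccc(O)c1` differs from compound 2 by hydroxy in place of nitro on an aromatic carbon. Among the measured compounds shown here, no step between measured compounds bears on such an exchange, so nothing here points in either direction; the step of a 1.0-fold higher number from compound 2 to compound 3 (0.02 log units; within the scatter) is expected to stay within the scatter. Compound 3 is therefore estimated at 30000 nM, with a range from 10000 nM to 90000 nM.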

Compound 3, half-maximal inhibitory concentration: 11800 nM
Compound 3: middle estimate off by 2.5-fold (0.41 log units), on the high side, within the range that was stated.
By their numbers in this assay, from the lowest: compound 3; then compounds 2 and 1 (each within the scatter of the next).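

In this assay, among these compounds, hydroxy in place of nitro gives a 2.4-fold lower number from compound 2 to compound 3 (0.39 log units; beyond the scatter) as a modest step, the first step here that can be read at all. It shows that this place on the aromatic ring, meta to a large group, is not indifferent to the group it carries, and that the smaller hydroxy does not raise the number. Nothing at hand accounts for the step. On these data alone, whether an amine or a methoxy group at this place would lower the number further stays open, as does whether the same exchange acts alike on another core.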